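Swapping a Methoxyphenyl for a Pyridyl Side Group

The source may hold more compounds than are shown below. What is called first, only, known or untested is meant among the compounds shown, and "the series" means these compounds.

Of the compounds shown here, two built on a shared core have been tested in an assay on isolated protein for inhibition of aldehyde dehydrogenase 1A1 (Homo sapiens); on this read-out higher numbers stand for weaker inhibition and lower numbers for stronger inhibition. Compound 1, with the structure `Cn1ncc2c(=O)n(-c3ccccc3)c(SCc3cccc(F)c3)cc21`, gives 240 nM in this assay. Compound 2, with the structure `COc1cccc(C(C)Sc2nc3c(cnn3C)c(=O)n2-c2ccccc2)c1`, gives 451 nM in this assay. The two values sit within the usual scatter of one another, so the numbers do not separate compound 1 from compound 2.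

Compound 3, with the structure `CC(Sc1nc2c(cnn2C)c(=O)n1-c1ccccc1)c1cccnc1`, has not yet been measured. It differs from compound 2 in a single place: pyridin-3-yl in place of 3-methoxyphenyl on a saturated chain carbon bound to a saturated chain carbon and a sulfur. Both the group that leaves and the group that enters carry one hydrogen-bond acceptor and no donor, and each is a single six-membered aromatic ring.

Going by the values given here, no measured pair shows what this particular exchange does in this assay, so the expectation rests on the narrow spread seen so far. A step from compound 2 to compound 3 of a 1.4-fold higher number from compound 2 to compound 3 (0.16 log units; within the scatter) is estimated, which would be a small loss, not clearly beyond the scatter. For compound 3 the estimated value in this assay is 650 nM, with a likely range from 220 nM to 2000 nM.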

Compound 3, half-maximal inhibitory concentration in the aldehyde dehydrogenase 1A1 assay: 139 nM
For compound 3 the middle estimate is 4.7-fold (0.67 log units) above the measured one, and the stated range ends above it.
By their numbers in the aldehyde dehydrogenase 1A1 assay, from the lowest: compounds 3, 1 and 2 (each within the scatter of the next, the first and the last beyond it).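

Going by these compounds alone, at the position on a saturated chain carbon bound to a saturated chain carbon and a sulfur, pyridin-3-yl in place of 3-methoxyphenyl gives a 3.2-fold lower number from compound 2 to compound 3 (0.51 log units; beyond the scatter) in the aldehyde dehydrogenase 1A1 assay, so this exchange moves the read-out by more than the scatter, whereas compounds 1 and 2, which differ in more than one place, offered no such step. In this pair, stronger inhibition also comes with a far higher measured solubility in a physicochemical assay for solubility, using the shake flask method, in phosphate buffer, with a stated time of 24 h, at pH 7.4; a higher number here means a more soluble compound, a lower number a less soluble compound: the measured solubility of compound 2, < 2000 nM, and of compound 3, 209000 nM, an at least 100-fold higher number (2.01 log units; beyond the scatter) For compound 2, the physicochemical assay gives < 2000 nM, which is a limit of the assay and not a number: the limit of < 2000 nM in the physicochemical assay, at which 1 of the 2 values shown sits. In the physicochemical assay compound 3 gives 209000 nM.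

With only this one exchange shown at the position, it remains open whether a plain phenyl, a pyridin-2-yl or a pyridin-4-yl group on the same carbon would track pyridin-3-yl or 3-methoxyphenyl in the aldehyde dehydrogenase 1A1 assay. From the compounds shown here alone, compound 1 differs from compounds 2 and 3 in more than one place, and what each of those differences contributes also stays open.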